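Cyclopropyl for ethyl on the side chain of compound 1

A few compounds are considered here, and "the series" means these few. Any claim that something is new, unique, unknown or untested is made for them only; others in the source may bear on it.

Measured compounds:
- compound 1, `CCC(COC)n1c(=O)c(C)nc2c(-c3cc(F)c(OC)cc3Cl)ccnc21`: 0.03
- compound 2, `CC[C@H](COC)n1c(=O)c(C)nc2c(-c3ccc(Cl)cc3Cl)ccnc21`: 0.004
- compound 3, `CCC(C1CC1)n1c(=O)c(C)nc2c(-c3cc(Cl)c(OC(F)F)cc3C)ncnc21`: 0.004

These three compounds were tested in an ADME assay on a cell-free system (plasma, Rattus norvegicus) for protein binding; on this read-out higher numbers stand for a larger free fraction and lower numbers for a smaller free fraction. Compound 1 gives 0.03, the highest of the three numbers; compound 2 gives 0.004 and compound 3 gives 0.004, both well beyond the usual scatter below compound 1. Compound 3 already carries a cyclopropyl on its side chain, but it differs from compound 1 in several other places, so its value alone cannot be traced to that group.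

The next compound, compound 4, `COCC(C1CC1)n1c(=O)c(C)nc2c(-c3cc(F)c(OC)cc3Cl)ccnc21`, keeps everything of compound 1 except one change: cyclopropyl in place of ethyl on a saturated chain carbon bound to an aromatic nitrogen and a saturated chain carbon. Going by the values given here, no measured pair shows this change on its own. The closest hint is that all compounds apart from compound 1 give markedly smaller free fractions in this assay, so a modest move downward is expected rather than none. The step from compound 1 to compound 4 is expected to be a 1.5-fold lower number from compound 1 to compound 4 (0.18 log units; within the scatter). Compound 4 is estimated at 0.02, between 0.008 and 0.04.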

Compound 4, unbound fraction: < 0.002
Compound 4: a limit, no number; the forecaster's own chance of this, stated with the estimate: 5%; middle value at least 10-fold (1.00 log units) from the limit.
By their numbers in this assay, from the lowest: compounds 2 and 3 (each within the scatter of the next); then compound 1. At a limit, below all of these: compound 4.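

In this assay compound 4 gives < 0.002, which is a limit of the assay and not a number. This is the first pair shown that differs in one place only, and replacing ethyl with cyclopropyl on a saturated chain carbon bound to an aromatic nitrogen and a saturated chain carbon gives an at least 15-fold lower number from compound 1 to compound 4 (1.17 log units; beyond the scatter), so a small change at this position can strongly reduce the free fraction. The full size of the step cannot be read, because compound 4 has no exact value: the limit of < 0.002 in this assay, at which 1 of the 4 values shown sits.

The compounds shown leave open whether an isopropyl or a tert-butyl group at this carbon would lower the free fraction as much, or how an amine on the chain would behave. They also do not show whether the same swap would act alike on compound 2, which differs from compound 1 elsewhere.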